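Solubility notes: ketone to cyclopropyl amide on the shared core

This account rests on a few compounds, and the source may have more. Where it says the series, first, only, none or still open, it means among the compounds named here.

Compound 1 `CCOC(=O)c1cc(-c2ccc(F)cc2)n(-c2ccc(I)cc2)c1` gives 300 nM in a physicochemical assay for solubility, read by HPLC, in phosphate buffer, measured as kinetic solubility, at pH 7.4; a lower number here means a less soluble compound, a higher number a more soluble compound. Compound 2 `CCCC(=O)c1cc(-c2ccc(S(N)(=O)=O)cc2)n(-c2ccc(Cl)cc2)n1` holds the highest of the two numbers: in this assay compound 2 gives 25800 nM, and the nearest number, that of compound 1, lies beyond the scatter. Compound 3 `NS(=O)(=O)c1ccc(-c2cc(C(=O)NC3CC3)nn2-c2ccc(Cl)cc2)cc1` is not yet measured; it differs from compound 2 by cyclopropylamino in place of propyl on a carbonyl carbon, propylcarbonyl becoming cyclopropylcarbamoyl with one hydrogen-bond donor entering. Going by the values given here, no measured step of this kind exists. The step of a 1.2-fold higher number from compound 2 to compound 3 (0.09 log units; within the scatter) is expected to be small and upward, probably within the scatter. Compound 3 is estimated at 32000 nM, with a range from 10000 nM to 90000 nM.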

Compound 3, solubility: 72600 nM
The estimate for compound 3 lay 2.3-fold (0.36 log units) below the measured number; the range from low to high includes it.
By their numbers in this assay, from the lowest: compound 1; then compound 2; then compound 3.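

The carbonyl carbon on the shared core now has its first measured change: in this assay, cyclopropylamino in place of propyl gives a 2.8-fold higher number from compound 2 to compound 3 (0.45 log units; beyond the scatter). The change from propylcarbonyl to cyclopropylcarbamoyl therefore moves the read-out modestly upward, rather than leaving it within the scatter. No measurement at hand accounts for this step.

The compounds shown leave open whether the step follows the three-membered ring or the amide hydrogen. A propylamino or dimethylamino group on the same carbonyl carbon would separate the two.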